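Swapping the arylidene ring: what compound 4 may show

This account rests on a few compounds, and the source may have more. Where it says the series, first, only, none or still open, it means among the compounds named here.

Three compounds have been measured in an ADME assay on WI-38 cells (Homo sapiens) for cytotoxicity, read by MTT assay, with a stated time of 72 h; on this read-out lower numbers stand for stronger inhibition and higher numbers for weaker inhibition:
- compound 1 `CN(C)CCn1cnnc1-c1cc(Oc2ccc(NC(=O)N/N=C/c3ccccc3O[N+](=O)[O-])cc2F)ccn1` gives 6860 nM
- compound 2 `CN(C)CCn1cnnc1-c1cc(Oc2ccc(NC(=O)N/N=C/c3ccc(F)cc3)cc2F)ccn1` gives 3980 nM
- compound 3 `CN(C)CCn1cnnc1-c1cc(Oc2ccc(NC(=O)N/N=C/c3ccc(Cl)cc3)cc2F)ccn1` gives 1870 nM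

Among these three, compound 3 has the lowest number, so it is the strongest inhibitor of cell growth in this assay; its steps to both others lie beyond the scatter, with a 3.7-fold lower number from compound 1 to compound 3 (0.56 log units; beyond the scatter) and a 2.1-fold lower number from compound 2 to compound 3 (0.33 log units; beyond the scatter).

Compound 4 `COc1cc(/C=N/NC(=O)Nc2ccc(Oc3ccnc(-c4nncn4CCN(C)C)c3)c(F)c2)ccc1O` has not been measured. It differs from compound 3 in one place: 4-hydroxy-3-methoxyphenyl in place of 4-chlorophenyl on a carbon with a double bond to nitrogen.

Among the measured compounds shown here, two measured steps bear on this change, since both also alter the ring attached to that same carbon. Going from compound 1 to compound 3 gave a 3.7-fold lower number from compound 1 to compound 3 (0.56 log units; beyond the scatter), and going from compound 2 to compound 3 gave a 2.1-fold lower number from compound 2 to compound 3 (0.33 log units; beyond the scatter). In both cases the 4-chlorophenyl end of compound 3 produced the lower number, and every other ring tried at that position gave a higher one. On that basis, compound 4 is expected to move away from compound 3 toward higher numbers, by a modest step of about a 2.7-fold higher number from compound 3 to compound 4 (0.43 log units; beyond the scatter). The estimate for compound 4 in this assay is therefore 5000 nM, with a range from 2000 nM to 14000 nM.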

Compound 4, half-maximal inhibitory concentration: 5320 nM
Compound 4: middle estimate off by 1.1-fold (0.03 log units), on the low side; measured number inside the range.
By their numbers in this assay, from the lowest: compound 3; then compounds 2, 4 and 1 (each within the scatter of the next).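

In this assay, the 4-hydroxy-3-methoxyphenyl ring, which brings a hydrogen-bond donor and two hydrogen-bond acceptors where 4-chlorophenyl has none, gives a 2.8-fold higher number from compound 3 to compound 4 (0.45 log units; beyond the scatter), so compound 3 now has the lowest number of four compounds, with its steps to all three others beyond the scatter. The new ring cannot be told apart from the two other rings, as both a 1.3-fold higher number from compound 2 to compound 4 (0.13 log units; within the scatter) and a 1.3-fold lower number from compound 1 to compound 4 (0.11 log units; within the scatter) stay within the scatter, which leaves 4-chlorophenyl as the only ring at this position that stands apart so far. Nothing available here explains why this ring stands apart from the others.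

The compounds shown leave open whether the chlorine itself matters or whether other groups in its place, such as bromo or methyl in a 4-bromophenyl or 4-methylphenyl ring, would give a similarly low number. They also cannot show whether the hydroxyl or the methoxy of compound 4 counts for more on its own, and a ring bearing an amine or a carboxylic acid would extend the comparison further.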